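This account rests on a few compounds, and the source may have more. Where it says the series, first, only, none or still open, it means among the compounds named here.

Measured compounds and their half-maximal effective concentrations:

Compound 1, `CC(C)(C)OC(=O)N1CCN(C(=O)c2cn(-c3ccc(C(F)(F)F)cc3)nn2)CC1`: 13.6 nM
Compound 2, `CC(C)(C)OC(=O)N1CCN(C(=O)c2cn(-c3nc4ccccc4s3)nn2)CC1`: 7.12 nM
Compound 3, `CC(C)(C)OC(=O)N1CCN(C(=O)c2cn(-c3ccc(S(C)(=O)=O)cc3F)nn2)CC1`: 12.4 nM

All three were tested in an assay on HEK293 cells for agonist activity at Glucose-dependent insulinotropic receptor (Homo sapiens), read by a luciferase reporter, with a stated time of 24 h; on this read-out lower numbers stand for an effect already at smaller amounts and higher numbers for an effect only at larger amounts of compound. Compound 3 holds the second highest of the three numbers; its nearest neighbour is compound 1, and the two lie within the scatter of each other, while compound 2 is the furthest from it, also within the scatter. Within the data shown here, the one single-point step among the measured compounds, a 1.9-fold lower number from compound 1 to compound 2 (0.28 log units; within the scatter), swaps the whole aromatic group on the ring nitrogen and is itself within the scatter.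

Compound 4, `CC(C)(C)OC(=O)N1CCN(C(=O)c2cn(-c3ccc(S(C)(=O)=O)cc3)nn2)CC1`, differs from compound 3 by hydrogen in place of fluoro on an aromatic carbon. Among the measured compounds shown here, no measured step removes a fluoro from this ring, so the only guidance is the general flatness of the series: the one step on the aromatic substituent stayed within the scatter, and the three values together span less than the scatter. On that basis compound 4 is expected to show essentially no step beyond the scatter, with a 1.0-fold higher number from compound 3 to compound 4 (0.02 log units; within the scatter) as the estimated step. The estimate for compound 4 is 13 nM, with a range from 5 nM to 35 nM.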

Compound 4, half-maximal effective concentration: 3.12 nM
The estimate for compound 4 lay 4.2-fold (0.62 log units) above the measured number, outside the stated range (below it).
By their numbers in this assay, from the lowest: compound 4; then compounds 2, 3 and 1 (each within the scatter of the next).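

In this assay, among these compounds, the fluoro on the aromatic carbon ortho to a large group and meta to a methylsulfonyl group proves not to be a silent substituent: its replacement by hydrogen gives the first step that clearly counts (a 4.0-fold lower number from compound 3 to compound 4 (0.60 log units; beyond the scatter)). Among the compounds shown here, with hydrogen there, the choice of aromatic group on the ring nitrogen also becomes readable, both for methylsulfonyl in place of trifluoromethyl (a 4.4-fold lower number from compound 1 to compound 4 (0.64 log units; beyond the scatter)) and for 4-(methylsulfonyl)phenyl in place of 1,3-benzothiazol-2-yl (a 2.3-fold lower number from compound 2 to compound 4 (0.36 log units; beyond the scatter)), whereas the one earlier step between aromatic groups stayed within the scatter. Nothing shown accounts for the size of these steps.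

On these data alone, it remains open whether a chloro or a methyl group on the same carbon would behave like fluoro or like hydrogen. As far as these compounds go, it is also open whether removing a fluoro would matter equally with trifluoromethyl in place of methylsulfonyl.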